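The source may hold more compounds than are shown below. What is called first, only, known or untested is meant among the compounds shown, and "the series" means these compounds.

Measured so far, in an ADME assay on isolated protein for pharmacokinetics, with UDP-glucuronosyltransferase 1A9 (Homo sapiens) as the target, read by LC-MS, with a stated time of 60 min, at 37 degrees C, tested at 1 uM, in the presence of a further agent that is not named here; a higher number here means that the compound lasts longer, a lower number that the compound disappears faster:

Compound 1 `NS(=O)(=O)CC(=O)NCCSc1nonc1/C(=N/O)Nc1ccc(F)c(C(F)F)c1` gives > 3 h, which is a limit of the assay, not a number.
Compound 2 `N#CCC(=O)NCCSc1nonc1/C(=N/O)Nc1ccc(F)c(C(F)F)c1` gives 1.73 h.
Compound 3 `CC(C)(O)CC(=O)NCCSc1nonc1/C(=N/O)Nc1ccc(F)c(C(F)F)c1` gives > 3 h, again a limit of the assay rather than a number.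

Compound 3 therefore stands at the ceiling of what this assay reports, and it shares that position with one other value: the limit of > 3 h in this assay, at which 2 of the 3 values shown sit. The step that the two limits leave unreadable from compound 1 to compound 3 cannot be read, as both ends are limits. The step of an at least 1.7-fold higher number from compound 2 to compound 3 (0.23 log units; that floor lies within the scatter) is a floor only, and the same is true in the other direction for an at least 1.7-fold lower number from compound 1 to compound 2 (0.23 log units; that floor lies within the scatter).

Compound 4 `CS(=O)(=O)CC(=O)NCCSc1nonc1/C(=N/O)Nc1ccc(F)c(C(F)F)c1` has not been measured. Its difference from compound 3 is methylsulfonyl in place of 1-hydroxy-1-methylethyl on a saturated chain carbon bound to a carbonyl carbon.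

Among the compounds with values here, the steps that bear on this change are those around the same saturated chain carbon bound to a carbonyl carbon. The cyano analogue, compound 2, is the only one of the three with a read number; the sulfamoyl and 1-hydroxy-1-methylethyl analogues both sit at the limit. Methylsulfonyl is closest in kind to sulfamoyl, the group on compound 1, and compound 1 sits at the limit too. On that basis the step of a number no higher from compound 3 to compound 4 (the limit leaves the size open) is expected to be small or none beyond the scatter, though the limit on compound 3 makes any estimate loose. Compound 4 is estimated at 3 h in this assay, within 1.5 h to 6 h, with a fair chance that only a limit is reported.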

Compound 4, half-life: 1.59 h
The estimate for compound 4 lay 1.9-fold (0.28 log units) above the measured number, and the stated range covers the measured number.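

In this assay, the saturated chain carbon bound to a carbonyl carbon now has a second read number, and methylsulfonyl reads alongside cyano there: a 1.1-fold lower number from compound 2 to compound 4 (0.04 log units; within the scatter), so these two groups cannot be told apart. The two sulfonyl groups are separated only by a floor, an at least 1.8-fold lower number from compound 1 to compound 4 (0.27 log units; that floor lies within the scatter), so methyl in place of amino on a sulfonyl sulfur gives a first hint, no more, that the sulfonyl groups need not read alike. Against 1-hydroxy-1-methylethyl the reading is again only a floor, an at least 1.8-fold lower number from compound 3 to compound 4 (0.27 log units; that floor lies within the scatter), and compound 1 and compound 3 remain the only compounds reported as limits, not numbers, a position that compound 4 does not share: the limit of > 3 h in this assay, at which 2 of the 4 values shown sit.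

As far as these compounds go, the true values of compound 1 and compound 3 remain unknown, so the full size of these steps cannot be read, and a real gap among the groups at this position is not yet established. Also open, from the compounds shown here alone, is whether a carboxylic acid, an amine or a longer chain on the same carbon would read with cyano and methylsulfonyl or reach the limit.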